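Propyl to cyclohexyl on the amine nitrogen of compound 1

A few compounds are considered here, and "the series" means these few. Any claim that something is new, unique, unknown or untested is made for them only; others in the source may bear on it.

Among the compounds with values here, compound 1 `CCCNC(=C\C(=O)/C=C/c1ccc(O)c(OC)c1)/C=C/c1ccc(O)c(OC)c1` is the weakest of the three measured members in a functional assay on EA.hy 926 cells (Homo sapiens), read by fluorescence, tested at 1 uM (on this read-out higher numbers stand for a stronger effect at the one concentration tested and lower numbers for a weaker effect), where compound 1 gives 78%. Compound 2 `COc1cc(/C=C/C(=O)/C=C(/C=C/c2ccc(OC(C)=O)c(OC)c2)NCC(C)C)ccc1OC(C)=O` gives 104% in this assay, a number beyond the scatter above that of compound 1, and compound 3 `COc1cc(/C=C/C(=O)CC(=O)/C=C/c2ccc(OC(C)=O)c(OC)c2)ccc1OC(C)=O` gives 114%, also beyond the scatter above compound 1. Neither compound 2 nor compound 3 differs from compound 1 in one place only, so no single change can be read from these three values.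

Compound 4 `COc1cc(/C=C/C(=O)/C=C(/C=C/c2ccc(O)c(OC)c2)NC2CCCCC2)ccc1O` is not yet measured. It differs from compound 1 by cyclohexyl in place of propyl on an amine nitrogen. Within the data shown here, no measured pair shows the effect of a change on the amine nitrogen alone, so the expectation rests on the value of compound 1 and the spread of the series. The step from compound 1 to compound 4 is expected to be small, not beyond the scatter in either direction, as a number 4 percentage points higher from compound 1 to compound 4 (within the scatter). Compound 4 is therefore estimated at 82%, with a range from 60% to 105%, in this assay.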

Compound 4, a percentage reported as activity, at one concentration (the size of the read-out at that concentration, not a potency): 91%
Compound 4: the middle estimate sits 9 percentage points below what was measured, and the stated range covers the measured number.
By their numbers in this assay, from the lowest: compound 1; then compound 4; then compounds 2 and 3 (each within the scatter of the next).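

Cyclohexyl in place of propyl on the amine nitrogen gives the first reading of a single change in this series: in this assay the swap is a number 13 percentage points higher from compound 1 to compound 4 (beyond the scatter), a modest gain. The earlier compounds shown here could not show that this position takes a ring of carbon only, with six heavy atoms against three, and that the number rises rather than falls. Nothing at hand bears on the reason for this rise.

From the compounds shown here alone, whether the gain follows the ring or only the larger carbon count stays open, and a straight hexyl chain or a cyclopentyl group on the same nitrogen would separate the two. Also open, going by these compounds, is how this position responds to groups beyond plain carbon, such as a benzyl group or a chain ending in a carboxylic acid.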